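Indazole versus substituted phenyl on the fused core

The source may hold more compounds than are shown below. What is called first, only, known or untested is meant among the compounds shown, and "the series" means these compounds.

Measured compounds in a functional assay on HeLa cells (Homo sapiens) for inhibition, read by CCK-8 assay, with a stated time of 48 h; on this read-out lower numbers stand for stronger inhibition and higher numbers for weaker inhibition:
compound 1, `COc1cc(-c2ccnc3cc(-c4ccc(Cl)cc4)nn23)cc(OC)c1OC`: 1490 nM
compound 2, `COc1cc(-c2ccnc3cc(-c4ccc(C(C)(C)C)cc4)nn23)cc(OC)c1OC`: > 10000 nM, a limit of the assay, not a number
compound 3, `COc1cc(-c2ccnc3cc(-c4ccc5cnn(C)c5c4)nn23)cc(OC)c1OC`: 97 nM

Compound 3 holds the lowest number of the two given as numbers; the nearest is compound 1, and the step of a 15-fold lower number from compound 1 to compound 3 (1.19 log units; beyond the scatter) lies beyond the scatter. Against compound 2 the step of an at least 100-fold lower number from compound 2 to compound 3 (2.01 log units; beyond the scatter) is larger still, though compound 2 only reached the assay limit (the limit of > 10000 nM in this assay, at which 1 of the 3 values shown sits). Between the two substituted phenyl compounds, the step of an at least 6.7-fold higher number from compound 1 to compound 2 (0.82 log units; beyond the scatter) also lies beyond the scatter.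

Compound 4, `COc1cc(-c2ccnc3cc(-c4ccc(C(F)(F)F)cc4)nn23)cc(OC)c1OC`, has not been measured. It differs from compound 3 in one place: 4-(trifluoromethyl)phenyl in place of 1-methyl-1H-indazol-6-yl on an aromatic carbon. The group entering is again a phenyl bearing one group, as in compound 1 and compound 2, so the reverse of the two steps onto compound 3 bear on it; both were large. A large upward step is therefore expected in this assay, estimated as a 26-fold higher number from compound 3 to compound 4 (1.41 log units; beyond the scatter). Compound 4 is expected to give about 2500 nM, in the range 700 nM to 10000 nM.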

Compound 4, half-maximal inhibitory concentration: 1840 nM
The estimate for compound 4 lay 1.4-fold (0.13 log units) above the measured number, within the range that was stated.
By their numbers in this assay, from the lowest: compound 3; then compounds 1 and 4 (each within the scatter of the next). At a limit, above all of these: compound 2.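

Across the phenyl compounds, the 1-methyl-1H-indazol-6-yl group now stands apart from a third substituent in this assay, with the step of a 19-fold higher number from compound 3 to compound 4 (1.28 log units; beyond the scatter). On the phenyl, trifluoromethyl and chloro are not told apart, with the step of a 1.2-fold higher number from compound 1 to compound 4 (0.09 log units; within the scatter), whereas trifluoromethyl in place of tert-butyl does move the read-out, with the step of an at least 5.4-fold lower number from compound 2 to compound 4 (0.73 log units; beyond the scatter), so the size of this step is open on one side. Compound 2 gives a limit of the assay, not a number: the limit of > 10000 nM in this assay, at which 1 of the 4 values shown sits.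

From the compounds shown here alone, whether the lower number of compound 3 depends on the ring nitrogens, the fused ring or the methyl group remains open. A phenyl bearing an amine or a carboxylic acid, or an indazol-6-yl without the methyl group, would help separate these.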